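The source may hold more compounds than are shown below. What is called first, only, known or untested is meant among the compounds shown, and "the series" means these compounds.

Compound 1 `CC(C)=CC[C@@H](OC(=O)c1ccco1)C1=CC(=O)c2c(O)ccc(O)c2C1=O` carries a (furan-2-yl)carbonyl ester on the shared core. In a functional assay on DU-145 cells (Homo sapiens) for cytotoxicity, read by MTT assay (on this read-out lower numbers stand for stronger inhibition and higher numbers for weaker inhibition), compound 1 gives only a limit, > 100000 nM. Two companions share that core. Compound 2 `CC[C@](C)(O)CC(=O)O[C@H](CC=C(C)C)C1=CC(=O)c2c(O)ccc(O)c2C1=O` gives 20500 nM in this assay, and compound 3 `CCCCC(CC(=O)O[C@H](CC=C(C)C)C1=CC(=O)c2c(O)ccc(O)c2C1=O)OC(C)=O` gives 67700 nM. Both steps away from compound 1 run toward lower numbers: an at least 4.8-fold lower number from compound 1 to compound 2 (0.68 log units; beyond the scatter) and an at least 1.4-fold lower number from compound 1 to compound 3 (0.16 log units; that floor lies within the scatter); each rests on the limit of > 100000 nM in this assay, at which 1 of the 3 values shown sits, and cannot be sized further. Between the two measured esters, a 3.3-fold higher number from compound 2 to compound 3 (0.52 log units; beyond the scatter).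

Compound 4 `CC(C)=CC[C@@H](OC(=O)C1CCOC1)C1=CC(=O)c2c(O)ccc(O)c2C1=O` is the compound not yet measured. It differs from compound 1 in one place: oxolan-3-yl in place of furan-2-yl on a carbonyl carbon. Within the data shown here, no measured step exchanges one five-membered ring for another, so the two steps out of compound 1 are the only guide, and both lead to lower numbers from an ester that registers only a limit. Compound 2 and compound 3 carry no aromatic ring in the acyl part, and compound 4 likewise brings a non-aromatic ring where compound 1 has an aromatic one. He therefore expects a step toward lower numbers, an at least 1.6-fold lower number from compound 1 to compound 4 (0.22 log units; that floor lies within the scatter), of uncertain size because the start is the limit (the limit of > 100000 nM in this assay, at which 1 of the 3 values shown sits). His estimate for compound 4 in this assay is 60000 nM, within 15000 nM to 200000 nM.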

Compound 4, half-maximal inhibitory concentration: 47500 nM
Estimate against measurement, compound 4: 1.3-fold (0.10 log units) above; the measured number falls inside the stated range.
By their numbers in this assay, from the lowest: compound 2; then compounds 4 and 3 (each within the scatter of the next). At a limit, above all of these: compound 1.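

Among these compounds, the exchange of furan-2-yl for oxolan-3-yl is the first step here that keeps a five-membered ring on the carbonyl carbon, and in this assay it changes the reading beyond the scatter (an at least 2.1-fold lower number from compound 1 to compound 4 (0.32 log units; beyond the scatter)). The true size of that step cannot be given, because compound 1 stands only at a limit: (the limit of > 100000 nM in this assay, at which 1 of the 4 values shown sits). A non-aromatic ring at this place thus sits within the scatter of the open acyl chain of compound 3 (a 1.4-fold lower number from compound 3 to compound 4 (0.15 log units; within the scatter)), while compound 2, with its 2-hydroxy-2-methylbutyl group, keeps the lowest number of the set (a 2.3-fold higher number from compound 2 to compound 4 (0.36 log units; beyond the scatter)).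

The compounds shown leave open whether the ring oxygen of oxolan-3-yl plays any part, a question that a cyclopentyl group or an oxolan-2-yl group at the same carbonyl carbon would address. They also leave open whether a hydroxyl group on the oxolan-3-yl ring would bring compound 4 to the number of compound 2.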